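The compounds below may be only part of what the source reports. "The series", "measured", "known", "first", "only" and "open" are said of these compounds alone.

Measured so far:
compound 1 `CCOc1ccc2nc(C(=O)Nc3c(F)cc(-c4cccc(F)c4)cc3F)c(C)c(O)c2c1` gives 2.03% in a functional assay on Hep 3B2 cells (Homo sapiens) for antiproliferative activity, read by MTT assay, with a stated time of 24 h, tested at 11.11 ug/mL; a lower number here means a weaker effect, a higher number a stronger effect of the compound at the concentration tested
compound 2 `Cc1c(C(=O)Nc2c(F)cc(-c3cccc(F)c3)cc2F)nc2ccc(C(F)(F)F)cc2c1O` gives 36.3% in this assay

Compound 2 stands highest of the two numbers; its nearest neighbour is compound 1, and the step of a number 34.3 percentage points higher from compound 1 to compound 2 (beyond the scatter) came with a trifluoromethyl in place of ethoxy on an aromatic carbon. Compound 3 `Cc1c(C(=O)Nc2c(F)cc(-c3cccc(F)c3)cc2F)nc2ccc(C(F)(F)F)cc2c1C(=O)O` differs from compound 2 by carboxy in place of hydroxy on an aromatic carbon. Among the measured compounds shown here, no measured step involves this change, so no direction can be drawn from the data. Compound 3 is therefore expected to stay near compound 2, with the expected step of a number 8.3 percentage points lower from compound 2 to compound 3 (within the scatter), and its estimate is 28%, in the range 5% to 55%.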

Compound 3, a percentage reported as inhibition, at one concentration (the size of the read-out at that concentration, not a potency): 31.2%
For compound 3 the middle estimate is 3.2 percentage points below the measured one; the measured number falls inside the stated range.
By their numbers in this assay, from the lowest: compound 1; then compounds 3 and 2 (each within the scatter of the next).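

Among the compounds shown here, the position opposite the ring nitrogen had not been varied in the earlier compounds. In this assay carboxy in place of hydroxy on this aromatic carbon gives a number 5.1 percentage points lower from compound 2 to compound 3 (within the scatter) so this larger group, with 3 heavy atoms against 1, leaves the reading within the scatter of compound 2. No supporting data bear on why these two compounds read alike.

From the compounds shown here alone, whether an amine or a methoxy group on this carbon would read the same remains open. So does whether carboxy would behave alike with ethoxy on the core, as in compound 1.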